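Removing a Methoxy Group from a Weak Inhibitor

This account rests on a few compounds, and the source may have more. Where it says the series, first, only, none or still open, it means among the compounds named here.

Compound 2 `C=C1CC[C@@]2(C(OC)[C@@H]1O)[C@@H](C(=O)O)CC[C@H]2C(C)C` was measured in an ADME assay on HEK293 cells for inhibition of 11-beta-hydroxysteroid dehydrogenase type 2 (Homo sapiens), read by HTRF, with a stated time of 2 h, in the presence of a further agent that is not named here; a lower number here means a stronger inhibitor, a higher number a weaker inhibitor. For compound 2 the result is only a limit of the assay, > 500000 nM. Compound 1 `CC1=CC[C@@]2(CC1=O)[C@@H](C(=O)O)CC[C@H]2C(C)C` also returns only a limit, > 500000 nM. Neither value is a number; the picture is the limit of > 500000 nM in this assay, at which 2 of the 2 values shown sit. Compound 3 `C=C1CC[C@@]2(C[C@@H]1O)[C@@H](C(=O)O)CC[C@H]2C(C)C` differs from compound 2 by hydrogen in place of methoxy on a saturated ring carbon. Within the data shown here, no measured pair covers this change, so no step beyond the scatter is expected in either direction, and the estimated step of a number no higher from compound 2 to compound 3 (the limit leaves the size open) is close to nothing. Compound 3 is thus expected near 500000 nM, within 150000 nM to 1500000 nM.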

Compound 3, half-maximal inhibitory concentration: > 500000 nM
Compound 3 gave a limit, no number; the forecaster's own chance of this, stated with the estimate: 85%; the middle value sits exactly at the limit.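

Compound 2 and compound 3 both return only a limit of the assay, so no step can be read between them. The compounds shown leave open whether swapping methoxy for hydrogen changes inhibition at all.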